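Butyl in Place of Amino: Expected Cytotoxicity of Compound 3

The source may hold more compounds than are shown below. What is called first, only, known or untested is meant among the compounds shown, and "the series" means these compounds.

Of the compounds shown here, two sharing one core have been tested in an ADME assay on cells (Splenocyte, Mus musculus, strain BALB/c) for cytotoxicity, read by CCK-8 assay, with a stated time of 48 h; on this read-out higher numbers stand for lower toxicity in this test and lower numbers for higher toxicity in this test. Compound 1, `COc1cc(-c2noc(-c3ccc(NC(=O)OC(C)(C)C)cc3)n2)cc(OC)c1OC`, gives 9200 nM. Compound 2, `COc1cc(-c2noc(-c3ccc(N)cc3)n2)cc(OC)c1OC`, reaches only the limit of the test, > 50000 nM, so no number is known for it. The step from compound 1 to compound 2 shows an at least 5.4-fold higher number from compound 1 to compound 2 (0.73 log units; beyond the scatter); that step is bounded by the limit of > 50000 nM in this assay, at which 1 of the 2 values shown sits. Compound 3, `CCCCc1ccc(-c2nc(-c3cc(OC)c(OC)c(OC)c3)no2)cc1`, has not been measured. It differs from compound 2 in one place: butyl in place of amino on an aromatic carbon. The only measured step that bears on this change is the one from compound 1 to compound 2, where a hydrogen took the place of tert-butoxycarbonyl on the nitrogen and the number rose by at least the amount shown. Among the compounds with values here, no measured step covers the exchange of amino for butyl itself; the nearest comparison is compound 1, which carried a larger group at the same place and gave 9200 nM. The expected step is an at least 3.3-fold lower number from compound 2 to compound 3 (0.52 log units; beyond the scatter), toward a lower number, with wide uncertainty since compound 2 is known only as a limit. Compound 3 is estimated at 15000 nM, between 5000 nM and 50000 nM.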

Compound 3, half-maximal cytotoxic concentration: 21200 nM
Beside the measured number, compound 3's estimate is 1.4-fold (0.15 log units) below it; low and high end bracket the measured number.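

In this assay, the place para to a large group on the six-membered aromatic ring now proves able to carry a butyl chain, with no nitrogen attached to the ring at that position, and the read-out still moves clearly: the exchange of amino for butyl gives an at least 2.3-fold lower number from compound 2 to compound 3 (0.37 log units; beyond the scatter). Compared with the (tert-butoxycarbonyl)amino group, butyl gives a 2.3-fold higher number from compound 1 to compound 3 (0.36 log units; beyond the scatter), so the earlier pair's contrast between the bare amino and its large substituted form now has a measured compound standing inside it, with compound 3 falling between compound 1 and the limit reached by compound 2. The size of the amino-to-butyl change remains only a bound, not a full measure: the limit of > 50000 nM in this assay, at which 1 of the 3 values shown sits.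

As far as these compounds go, how a shorter chain such as methyl, a longer chain such as hexyl or a branched tert-butyl group would stand at this place remains open, so the three compounds give no trend with chain length. Also open, from the compounds shown here alone, is whether a carboxylic acid or a hydroxyl group here would fall nearer to compound 2 or to compound 3, and what number compound 2 itself would give.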